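Bromine for nitrile on the benzyloxy arm of a flavone

A few compounds are considered here, and "the series" means these few. Any claim that something is new, unique, unknown or untested is made for them only; others in the source may bear on it.

Measured compounds in a functional assay on U-251 cells (Homo sapiens) for antiproliferative activity, read by MTT assay, with a stated time of 24 h; a higher number here means a weaker inhibitor, a lower number a stronger inhibitor:
compound 1 `COc1cc(OC)c(-c2coc3cc(OCc4ccccc4)ccc3c2=O)cc1OC` gives 6750 nM
compound 2 `COc1cc(OC)c(-c2coc3cc(OCc4ccccc4C#N)ccc3c2=O)cc1OC` gives 980 nM

Among the compounds with values here, compound 2 stands as the lower of the two numbers in this assay, with compound 1 as its only neighbour; the single measured step, a 6.9-fold lower number from compound 1 to compound 2 (0.84 log units; beyond the scatter), is the whole of what is known about this series so far.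

Compound 3 `COc1cc(OC)c(-c2coc3cc(OCc4cccc(Br)c4)ccc3c2=O)cc1OC` has not yet been measured. It differs from compound 2 at one place: 3-bromophenyl in place of 2-cyanophenyl on a saturated chain carbon bound to an oxygen on an aromatic ring. Put the other way, the (2-cyanobenzyl)oxy of compound 2 becomes (3-bromobenzyl)oxy in compound 3.

Within the data shown here, no measured step matches this change directly. Among the measured compounds shown here, the only step that bears on it is a 6.9-fold lower number from compound 1 to compound 2 (0.84 log units; beyond the scatter), which shows that the benzyl group can move the number by a modest amount when a cyano is added. Compound 3 keeps a substituted benzyl but loses the cyano, so the expectation is for a number somewhere between those of compound 1 and compound 2, that is a step of about a 2.6-fold higher number from compound 2 to compound 3 (0.41 log units; beyond the scatter) relative to compound 2. Compound 3 is therefore estimated at 2500 nM, within a range of 800 nM to 8000 nM.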

Compound 3, half-maximal inhibitory concentration: > 10000 nM
Compound 3 ended at the assay's limit; the forecaster's own chance of this, stated with the estimate: 5%; at least 4.0-fold (0.60 log units) between middle value and limit.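

In this assay, within the data shown here, compound 3 gives > 10000 nM, which is a limit of the assay and not a number, and it is the one reading in this short series that stands there: the limit of > 10000 nM in this assay, at which 1 of the 3 values shown sits. The earlier compounds shown here showed only that adding a nitrile to the benzyl ring lowers the number, whereas an at least 10-fold higher number from compound 2 to compound 3 (1.00 log units; beyond the scatter) shows that a substituted benzyl alone does not keep that gain and that the change from 2-cyanophenyl to 3-bromophenyl at this place costs clearly more than the scatter. Against the unsubstituted benzyl the picture is less firm: an at least 1.4-fold higher number from compound 1 to compound 3 (0.17 log units; that floor lies within the scatter) has a floor within the scatter, so bromo in place of hydrogen is not shown to make compound 3 weaker than compound 1, only not to bring the lowering that the nitrile brought.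

Since 2-cyanophenyl and 3-bromophenyl differ in both the group and its place on the ring, the compounds shown do not tell which of the two accounts for the loss. From the compounds shown here alone, how an amine or a carboxylic acid on that benzyl ring would read in this assay also stays open.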